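Acetyl to Dimethylamino: An Expected Gain in Cytotoxicity

The compounds below may be only part of what the source reports. "The series", "measured", "known", "first", "only" and "open" are said of these compounds alone.

Measured so far:
compound 1 `COc1cc(C)cc(-c2c(-c3ccnc(-c4ccc(C(C)=O)cc4)c3)cnn2CC#N)c1` gives 72%
compound 2 `COc1cc(C)cc(-c2nn(CC#N)cc2-c2ccnc(-c3ccc(N(C)C)cc3)c2)c1` gives 15%

In a functional assay on OVCAR-5 cells (Homo sapiens) for cytotoxicity, read by sulforhodamine B assay, with a stated time of 48 h, tested at 10 uM (a higher number here means a weaker effect of the compound at the concentration tested, a lower number a stronger effect), compound 1 stands highest of the two numbers; compound 2 lies far lower, beyond the scatter, and already carries a dimethylamino group on a differently arranged core. Compound 3 `COc1cc(C)cc(-c2c(-c3ccnc(-c4ccc(N(C)C)cc4)c3)cnn2CC#N)c1` is compound 1 with one change: dimethylamino in place of acetyl on an aromatic carbon. Among the compounds with values here, no measured pair shows this exact step, so the size is uncertain, but a drop toward stronger effect is expected, as a number 42 percentage points lower from compound 1 to compound 3 (beyond the scatter). Compound 3 is estimated at 30%, between 10% and 60%.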

Compound 3, a percentage reported as activity, at one concentration (the size of the read-out at that concentration, not a potency): 97%
Compound 3: middle estimate off by 67 percentage points, on the low side, outside the stated range (above it).
By their numbers in this assay, from the lowest: compound 2; then compound 1; then compound 3.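

Replacing acetyl with dimethylamino on this aromatic carbon gives a number 25 percentage points higher from compound 1 to compound 3 (beyond the scatter) in this assay and so a weaker effect on this core. The position is therefore sensitive to the group it carries, even between two groups with the same heavy-atom count, and dimethylamino does not bring a stronger effect here. Nothing measured here explains this shift.

The compounds shown leave open how a primary amine or a carboxylic acid would behave at this position. They also leave open whether a longer chain on the amine nitrogen would change the effect.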